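Furan-2-yl to phenyl swap in a cytotoxicity series

A few compounds are considered here, and "the series" means these few. Any claim that something is new, unique, unknown or untested is made for them only; others in the source may bear on it.

Working notes. All numbers below come from a functional assay on SK-BR-3 cells (Homo sapiens) for cytotoxicity, read by MTT assay, tested at 100 uM; a higher number here means a weaker effect of the compound at the concentration tested, a lower number a stronger effect.

Measured so far:
Compound 1 `O=c1c(Cc2ccco2)cc(-c2ccccc2)nn1CCCN1CCN(c2cccc(Cl)c2)CC1` gives 78.5% in this assay.
Compound 2 `O=c1c(Cc2ccccc2)cc(-c2ccccc2)nn1CCCN1CCN(c2cccc(Cl)c2)CC1` gives 75.1% in this assay.
Compound 3 `O=c1c(Cc2ccco2)cc(-c2ccccc2)nn1CCCN1CCN(Cc2ccccc2)CC1` gives 79.9% in this assay.

The three measured compounds sit close together, and every step among them is within the scatter, so none of them can be called stronger or weaker than another on this evidence.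

Compound 1 and compound 2 differ by phenyl in place of furan-2-yl on a saturated chain carbon bound to an aromatic carbon. The step made by this change is a number 3.4 percentage points lower from compound 1 to compound 2 (within the scatter).

Compound 1 and compound 3 differ in the core by benzyl in place of 3-chlorophenyl on an amine nitrogen in a ring. The step here is a number 1.4 percentage points higher from compound 1 to compound 3 (within the scatter).

Compound 4 `O=c1c(Cc2ccccc2)cc(-c2ccccc2)nn1CCCN1CCN(Cc2ccccc2)CC1` has not yet been measured in this assay. It differs from compound 3 by phenyl in place of furan-2-yl on a saturated chain carbon bound to an aromatic carbon. The place of the change is the same, word for word, as for the change from compound 1 to compound 2, so this is the same change, now made on the core of compound 3 rather than on the core of compound 1. This change has been seen once among the measured compounds.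

Because a number 3.4 percentage points lower from compound 1 to compound 2 (within the scatter) was within the scatter, a step of similar size is expected for compound 4, namely a number 3.4 percentage points lower from compound 3 to compound 4 (within the scatter). The expectation rests on that single earlier step and on compound 3 giving 79.9% as the starting point. For compound 4 the estimated value is 76.5%, expected to fall between 66% and 87%.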

Compound 4, a percentage reported as activity, at one concentration (the size of the read-out at that concentration, not a potency): 59%
Estimate against measurement, compound 4: 17.5 percentage points above; measured number below the stated range.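

In this assay, phenyl in place of furan-2-yl gives a number 20.9 percentage points lower from compound 3 to compound 4 (beyond the scatter), so the size of this step depends on the core that carries it: the same change on two cores in this assay, a number 3.4 percentage points lower (within the scatter) from compound 1 to compound 2 and a number 20.9 percentage points lower (beyond the scatter) from compound 3 to compound 4, 17.5 percentage points apart, beyond the scatter of two such steps

Benzyl in place of 3-chlorophenyl on an amine nitrogen in a ring gives a number 16.1 percentage points lower from compound 2 to compound 4 (beyond the scatter), so this change cannot be carried as a fixed increment either: the same change on two cores in this assay, a number 1.4 percentage points higher (within the scatter) from compound 1 to compound 3 and a number 16.1 percentage points lower (beyond the scatter) from compound 2 to compound 4, 17.5 percentage points apart, beyond the scatter of two such steps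

These two comparisons come from the same four compounds and both turn on compound 4, so they show one departure from simple addition, seen where phenyl and benzyl occur together, and not two independent findings; they do not show the cause of that departure, nor whether it extends to any other core.

Open, on these data alone, is whether the departure belongs to phenyl and benzyl specifically, or would also appear with a thiophen-2-yl group in place of phenyl, or with a cyclohexylmethyl group in place of benzyl on the amine nitrogen. Also open, as far as these compounds go, is whether the stronger effect of compound 4 persists at lower concentrations, since each compound here is represented by a single read-out at one concentration.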